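The source may report more compounds than this note shows. Statements on the series, on what has been measured and on what is new or still open speak of the compounds shown alone.

Measured so far:
Compound 1, `COc1nc2ccc(Br)cc2cc1C(c1ccccc1)n1cc(-c2ccc(Br)cc2)nn1`, gives 10.4% in an ADME assay on PANC-1 cells (Homo sapiens) for cytotoxicity, read by sulforhodamine B assay, with a stated time of 48 h, tested at 10 uM; a lower number here means less inhibition, a higher number more inhibition at the concentration tested (going by the name of the read-out).
Compound 2, `CCCCCCCc1cn(C(c2ccccc2)c2cc3cc(Br)ccc3nc2OC)nn1`, gives 16.6% in this assay.
Compound 3, `CCOC(=O)c1cn(C(c2ccccc2)c2cc3cc(Br)ccc3nc2OC)nn1`, gives 15.4% in this assay.

All three compounds share the same core and differ only in the group carried on the five-membered ring with three nitrogens. On the numbers shown, compound 3 sits among the other two: the step of a number 5 percentage points higher from compound 1 to compound 3 (within the scatter) and the step of a number 1.2 percentage points lower from compound 2 to compound 3 (within the scatter) are both within the scatter, so the numbers of the three compounds are level here.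

The next compound, compound 4, `CCCCCc1cn(C(c2ccccc2)c2cc3cc(Br)ccc3nc2OC)nn1`, takes the step (pentyl in place of ethoxycarbonyl on an aromatic carbon). The measured steps that bear on it are a number 6.2 percentage points higher from compound 1 to compound 2 (within the scatter), a number 5 percentage points higher from compound 1 to compound 3 (within the scatter) and a number 1.2 percentage points lower from compound 2 to compound 3 (within the scatter); none of them moved the number beyond the scatter, even when a heptyl or an ethoxycarbonyl replaced a 4-bromophenyl. A pentyl chain is in the same direction as the heptyl of compound 2, so no step beyond the scatter is expected in this assay. Compound 4 is therefore expected at 15%, between 5% and 25%, a step of a number 0.4 percentage points lower from compound 3 to compound 4 (within the scatter) that is expected to stay within the scatter.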

Compound 4, a percentage reported as inhibition, at one concentration (the size of the read-out at that concentration, not a potency): 5.07%
The estimate for compound 4 lay 9.9 percentage points above the measured number; the measured number falls inside the stated range.
By their numbers in this assay, from the lowest: compounds 4, 1, 3 and 2 (each within the scatter of the next, the first and the last beyond it).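

Unlike the earlier steps, which all stayed within the scatter, these results show that the group at this position of the shared core can change the number in this assay beyond the scatter. Pentyl in place of ethoxycarbonyl gives a number 10.3 percentage points lower from compound 3 to compound 4 (beyond the scatter) and, between the two chains, pentyl in place of heptyl gives a number 11.5 percentage points lower from compound 2 to compound 4 (beyond the scatter) as a further modest step, so these two chains do not read as equivalent here. Pentyl in place of 4-bromophenyl, by contrast, gives a number 5.3 percentage points lower from compound 1 to compound 4 (within the scatter) and separates those two groups no more than the scatter allows.

With only two chains shown, it remains open whether the number follows chain length at all, or how a butyl chain or a chain longer than heptyl would read. An amine or a carboxylic acid at this position is also an open case, and nothing shown gives a reason for these steps.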